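Fluoro to Methoxy: What to Expect for Compound 4

The source may hold more compounds than are shown below. What is called first, only, known or untested is meant among the compounds shown, and "the series" means these compounds.

Compound 1, `COc1ccc(-c2cc3cc(-c4ccccc4)cc(C(C)=O)c3[nH]2)cc1`: 43.5%
Compound 2, `COc1ccc(-c2cc3cc(-c4ccc(F)cc4)cc(C(C)=O)c3[nH]2)cc1`: 47%
Compound 3, `CC(=O)c1cc(/C=C/c2ccc(F)cc2)cc2cc(-c3ccc(F)cc3)[nH]c12`: 42.2%

All three were tested in a functional assay on MCF7 cells (Homo sapiens) for cytotoxicity, read by MTT assay, with a stated time of 2 days, tested at 100 uM; on this read-out higher numbers stand for a weaker effect at the one concentration tested and lower numbers for a stronger effect. Compound 3 gives the lowest of the three numbers, yet its gaps to compound 1 and to compound 2 both fall within the scatter, so no order among them can be claimed. Compound 4, `COc1ccc(-c2cc3cc(/C=C/c4ccc(F)cc4)cc(C(C)=O)c3[nH]2)cc1`, has not yet been measured; it differs from compound 3 by methoxy in place of fluoro on an aromatic carbon. Going by the values given here, the only measured step, a number 3.5 percentage points higher from compound 1 to compound 2 (within the scatter), concerns fluoro in place of hydrogen and lay within the scatter; no measured step shows methoxy in place of fluoro. With no sign that a change of this kind moves the read-out, the expected step of a number 1.8 percentage points higher from compound 3 to compound 4 (within the scatter) is none beyond the scatter. Compound 4 is therefore estimated at 44%, between 33% and 55%.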

Compound 4, a percentage reported as activity, at one concentration (the size of the read-out at that concentration, not a potency): 47.6%
Estimate against measurement, compound 4: 3.6 percentage points below, within the range that was stated.
By their numbers in this assay, from the lowest: compounds 3, 1, 2 and 4 (each within the scatter of the next).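

In this assay, going by these compounds alone, the change from 4-fluorophenyl to 4-methoxyphenyl gives a number 5.4 percentage points higher from compound 3 to compound 4 (within the scatter), the first measured look at methoxy in place of fluoro, and so far this position tolerates the swap without a clear change. With methoxy held in place, changes elsewhere on the core also stay small: 2-(4-fluorophenyl)ethenyl in place of 4-fluorophenyl gives a number 0.6 percentage points higher from compound 2 to compound 4 (within the scatter), and in place of phenyl it gives a number 4.1 percentage points higher from compound 1 to compound 4 (within the scatter). Nothing available explains these small steps. On these data alone, whether an amine, a carboxylic acid or a longer chain in the same place would move the read-out beyond the scatter remains open.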